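Removing One Methoxy From an Aminoaryl Vinyl Sulfone

The source may hold more compounds than are shown below. What is called first, only, known or untested is meant among the compounds shown, and "the series" means these compounds.

Compound 1 `COc1cc(OC)c(/C=C/S(=O)(=O)Cc2ccc(OC)c(N)c2)c(OC)c1` carries three methoxy groups on one aromatic ring, a vinyl sulfone link, and an amino group on the other ring. In a functional assay on T47D cells (Homo sapiens) for cytotoxicity, read by MTT assay, with a stated time of 72 h (a higher number here means a weaker inhibitor of growth, a lower number a stronger inhibitor of growth), compound 1 gives "not determined" (no result reported), so no number of its own exists. Two relatives were measured. Compound 2 `COc1ccc(CS(=O)(=O)/C=C/c2ccc(OC)c(OC)c2OC)cc1[N+](=O)[O-]` reaches only a limit of the assay in this assay, where compound 2 gives > 30000 nM. Compound 3 `COc1cc(/C=C/S(=O)(=O)Cc2ccc(OC)c([N+](=O)[O-])c2)cc(OC)c1` likewise reaches only a limit in this assay, where compound 3 gives > 30000 nM. Compound 1 therefore stands among values that are limits, not numbers, namely (the limit of > 30000 nM in this assay, at which 2 of the 3 values shown sit).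

Compound 4 `COc1ccc(CS(=O)(=O)/C=C/c2c(OC)cccc2OC)cc1N` is the next compound. It differs from compound 1 by hydrogen in place of methoxy on an aromatic carbon, in words hydrogen in place of methoxy on an aromatic carbon. For the measured compounds named here, no measured pair shows the size of such a step here, so how far it moves the result in this assay cannot be read from the numbers at hand: it could stay within the usual scatter or move in either direction. Given only limits around it, compound 4 is expected to give about 8000 nM, with a range from 300 nM to 30000 nM, and a limit rather than a number remains possible.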

Compound 4, concentration for 50% growth inhibition: 50 nM
Estimate against measurement, compound 4: 160-fold (2.20 log units) above, and the stated range ends above it.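

In this assay, for the compounds shown here, compound 4 gives 50 nM, while compound 1 gives "not determined" (no result reported), so no step between compound 1 and compound 4 can be read. The other values offer no number for comparison either: the limit of > 30000 nM in this assay, at which 2 of the 4 values shown sit. The compounds shown leave open how far hydrogen in place of methoxy on an aromatic carbon moves growth inhibition.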